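Chlorostyryl Analogue Versus Biaryl in Bile Acid Receptor Binding

This account rests on a few compounds, and the source may have more. Where it says the series, first, only, none or still open, it means among the compounds named here.

Measured compounds:
Compound 1, `COC(=O)/C=C/c1cccc(N(Cc2ccc(/C=C/c3c(F)cccc3F)cc2)C(=O)C(C)C)c1`, 108 nM
Compound 2, `COC(=O)/C=C/c1cccc(N(Cc2ccc(/C=C/c3ccc(F)cc3)cc2)C(=O)C(C)C)c1`, 120 nM
Compound 3, `COC(=O)/C=C/c1cccc(N(Cc2ccc(-c3cc(Cl)ccc3OC)cc2)C(=O)C(C)C)c1`, 226 nM

Of the compounds shown here, three sharing one core have been tested in an assay on isolated protein with Bile acid receptor (Homo sapiens) as the target; a lower number here means that less compound is needed, a higher number that more compound is needed for the effect. Compound 3 gives the highest number of the three; compound 2 is nearest to it, and the gap to compound 1 is the largest, with a 2.1-fold higher number from compound 1 to compound 3 (0.32 log units; beyond the scatter) while a 1.9-fold higher number from compound 2 to compound 3 (0.27 log units; within the scatter).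

Compound 4, `COC(=O)/C=C/c1cccc(N(Cc2ccc(/C=C/c3cccc(Cl)c3)cc2)C(=O)C(C)C)c1`, has not yet been measured. It differs from compound 3 in one place: 2-(3-chlorophenyl)ethenyl in place of 5-chloro-2-methoxyphenyl on an aromatic carbon. This change returns the compound to the arrangement seen in compounds 1 and 2, where a substituted phenyl ring is attached through a double-bonded two-carbon chain rather than directly.

Among the compounds with values here, the steps that bear on this change are those from compound 1 and from compound 2 to compound 3. Both run in the same direction, and the one that is beyond the scatter, a 2.1-fold higher number from compound 1 to compound 3 (0.32 log units; beyond the scatter), is modest. The difference between compounds 1 and 2, a 1.1-fold higher number from compound 1 to compound 2 (0.05 log units; within the scatter), shows that the halogen pattern on the distal ring had little effect in those two cases. Running the change in reverse, compound 4 is expected to give a lower number than compound 3, with an expected step of a 1.9-fold lower number from compound 3 to compound 4 (0.27 log units; within the scatter), landing near compounds 1 and 2. The estimate for compound 4 in this assay is 120 nM, with a range from 60 nM to 250 nM.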

Compound 4, half-maximal effective concentration: 164 nM
Estimate against measurement, compound 4: 1.4-fold (0.14 log units) below; the measured number falls inside the stated range.
By their numbers in this assay, from the lowest: compounds 1, 2, 4 and 3 (each within the scatter of the next, the first and the last beyond it).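

Compound 4 shows that this place, on an aromatic carbon para to a large group, accepts 2-(3-chlorophenyl)ethenyl as well as 5-chloro-2-methoxyphenyl in this assay without a separation beyond the scatter, as the step (a 1.4-fold lower number from compound 3 to compound 4 (0.14 log units; within the scatter)) shows. The earlier compounds shown here left open whether the ethenyl-linked arrangement and the directly attached ring could be told apart, and the one gap beyond the scatter, between compound 1 and compound 3, now has compound 4 within the scatter of both ends. On the ethenyl-linked ring, 3-chlorophenyl also stays within the scatter of 4-fluorophenyl (a 1.4-fold higher number from compound 2 to compound 4 (0.14 log units; within the scatter)) and of 2,6-difluorophenyl (a 1.5-fold higher number from compound 1 to compound 4 (0.18 log units; within the scatter)), so compounds 1, 2 and 4 form one group in this assay, with three different halogen patterns.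

The compounds shown leave open how this place would respond to a ring carrying an amine instead of a halogen, or to a longer chain in place of the ethenyl link. They also leave open what a carboxylic acid in place of the methyl ester would do to these numbers. Nothing available here explains any of these numbers.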